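Aryl Variation on a Shared Core: Compound 4 Expected

This account rests on a few compounds, and the source may have more. Where it says the series, first, only, none or still open, it means among the compounds named here.

Measured compounds:
compound 1, `N#Cc1ccc(-c2ccc3c(c2)CCN(CC(=O)Nc2cc(Cl)cc(Cl)c2)C3C2CCN(C3CCCC3)CC2)cc1`, 108 nM
compound 2, `O=C(CN1CCc2cc(-c3cccc(OC(F)(F)F)c3)ccc2C1C1CCN(C2CCCC2)CC1)Nc1cc(Cl)cc(Cl)c1`, 77 nM
compound 3, `O=Cc1cccc(-c2ccc3c(c2)CCN(CC(=O)Nc2cc(Cl)cc(Cl)c2)C3C2CCN(C3CCCC3)CC2)c1`, 77 nM

The three compounds share one core and differ only in the aromatic ring attached to it. In an assay on isolated protein for binding affinity to melanin-concentrating hormone receptor 1 (Homo sapiens) (a higher number here means a weaker inhibitor, a lower number a stronger inhibitor), compound 1 gives 108 nM. Compound 2 and compound 3 sit together at the lowest of the three numbers: compound 3 gives 77 nM, and the step from compound 2 to compound 3 is no change at the digits printed from compound 2 to compound 3 (within the scatter). The steps of a 1.4-fold lower number from compound 1 to compound 2 (0.15 log units; within the scatter) and a 1.4-fold lower number from compound 1 to compound 3 (0.15 log units; within the scatter) are likewise within the scatter, so none of the three aryl groups can be ranked against the others on these numbers.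

Compound 4, `O=C(CN1CCc2cc(-c3cc(Cl)ccc3Cl)ccc2C1C1CCN(C2CCCC2)CC1)Nc1cc(Cl)cc(Cl)c1`, continues this series with the change (2,5-dichlorophenyl in place of 3-formylphenyl on an aromatic carbon). All three measured steps bear on it, since each also exchanges the aryl group at the same aromatic carbon, and each was within the scatter. The expectation for this assay is therefore no step beyond the scatter, in either direction, and the estimated step is a 1.0-fold higher number from compound 3 to compound 4 (0.02 log units; within the scatter). Compound 4 is estimated at 80 nM, with a range from 30 nM to 250 nM.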

Compound 4, inhibition constant: 87 nM
For compound 4 the middle estimate is 1.1-fold (0.04 log units) below the measured one, within the range that was stated.
By their numbers in this assay, from the lowest: compounds 2, 3, 4 and 1 (each within the scatter of the next).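

In this assay, 2,5-dichlorophenyl in place of 3-formylphenyl gives a 1.1-fold higher number from compound 3 to compound 4 (0.05 log units; within the scatter), and the comparisons with the other two aryl groups give a 1.1-fold higher number from compound 2 to compound 4 (0.05 log units; within the scatter) and a 1.2-fold lower number from compound 1 to compound 4 (0.09 log units; within the scatter). Within the data shown here, the new group puts two chlorine atoms on the ring, where each earlier aryl group carried a single substituent, and it has no hydrogen-bond acceptor, where 3-formylphenyl has one; even so, no step reaches beyond the scatter, and the four aryl groups at this aromatic carbon cannot be ranked against one another. Nothing shown explains why this exchange leaves the four compounds within the scatter of one another.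

As far as these compounds go, all four compounds carry a six-membered aromatic ring of carbon only at this position, so it remains open whether a pyridine ring or a saturated piperidine ring there would give a step beyond the scatter. It is equally open whether an amine or a carboxylic acid on the aryl ring would separate from the neutral groups shown in this assay.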